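The source may hold more compounds than are shown below. What is called first, only, known or untested is meant among the compounds shown, and "the series" means these compounds.

Series notes. Compound 1 `CCCCNc1nc(N)nc2c1CN(C)CC2` carries a methyl on the ring nitrogen of the shared core; in an assay on HEK293 cells for agonist activity at Toll-like receptor 8 (Homo sapiens), read by a luciferase reporter, with a stated time of 6 h (a higher number here means that more compound is needed for the effect, a lower number that less compound is needed), compound 1 gives 0.03 uM, the lowest number among the three measured compounds. Compound 2 `CCCCNc1nc(N)nc2c1CN(Cc1ccc(C(C)(C)C)cc1)CC2` gives 0.66 uM in this assay, and compound 3 `CCCCNc1nc(N)nc2c1CN(Cc1ccc(-c3ccccc3)cc1)CC2` gives 0.5 uM; the step of a 1.3-fold lower number from compound 2 to compound 3 (0.12 log units; within the scatter) lies within the scatter. Compound 4 `CCCCNc1nc(N)nc2c1CN(C(=O)c1cnccn1)CC2` is not yet measured; it differs from compound 1 by (pyrazin-2-yl)carbonyl in place of methyl on an amine nitrogen in a ring. Among the measured compounds shown here, no measured step touches this ring nitrogen: the only step, from compound 2 to compound 3, changes a group elsewhere. Only the values of compounds 2 and 3, each with a larger group on this nitrogen and each a higher number than compound 1, bear on it. For compound 4 a higher number is therefore expected, a step of a 10-fold higher number from compound 1 to compound 4 (1.00 log units; beyond the scatter), giving an estimate of 0.3 uM with a range from 0.05 uM to 2 uM.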

Compound 4, minimum effective concentration: 2.2 uM
For compound 4 the middle estimate is 7.3-fold (0.87 log units) below the measured one; the measured number lies above the stated range.
By their numbers in this assay, from the lowest: compound 1; then compounds 3 and 2 (each within the scatter of the next); then compound 4.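

In this assay, among the compounds shown here, this is the first measured step on the ring nitrogen itself: (pyrazin-2-yl)carbonyl in place of methyl gives a 73-fold higher number from compound 1 to compound 4 (1.87 log units; beyond the scatter) and is large. Compound 4, the only compound shown with a carbonyl on this nitrogen, has the highest number of the four. Nothing available accounts for the size of this step.

Still open, as far as these compounds go, is whether the carbonyl or the pyrazine ring carries the step, which an acetyl or benzoyl group on this nitrogen would separate. Also open, from the compounds shown here alone, is how an ethyl group here compares with the methyl of compound 1.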